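This account rests on a few compounds, and the source may have more. Where it says the series, first, only, none or still open, it means among the compounds named here.

In a functional assay on microsomes for inhibition, with a stated time of 1 h (a higher number here means a weaker inhibitor, a lower number a stronger inhibitor), compound 2 `CCOC(=O)c1cnn(-c2nc(-c3cccc(O)c3O)c(C#N)c(=O)n2C)c1N` gives 49 ug/mL and compound 1 `CCOC(=O)c1cnn(-c2nc(-c3ccc(OC)cc3)c(C#N)c(=O)n2C)c1N` gives 68 ug/mL. These two numbers lie within the scatter of repeated measurements, so neither compound can be ranked above the other. Compound 3 `CCOC(=O)c1cnn(-c2nc(-c3ccc(Cl)cc3)c(C#N)c(=O)n2C)c1N` has not yet been measured. It has 4-chlorophenyl in place of the 2,3-dihydroxyphenyl of compound 2 on an aromatic carbon, ortho to a cyano group: 4-chlorophenyl in place of 2,3-dihydroxyphenyl on an aromatic carbon. Among the measured compounds shown here, only one measured step changes the group at this place, and it is a 1.4-fold lower number from compound 1 to compound 2 (0.14 log units; within the scatter), which stays within the scatter. A single step is thin evidence, but it gives no reason to expect a large move in this assay. The expected result is a 1.2-fold higher number from compound 2 to compound 3 (0.09 log units; within the scatter), which would be no real change beyond the scatter. For compound 3 the estimated value is 60 ug/mL, with an expected range from 25 ug/mL to 130 ug/mL.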

Compound 3, half-maximal inhibitory concentration: 88 ug/mL
Estimate against measurement, compound 3: 1.5-fold (0.17 log units) below, within the range that was stated.
By their numbers in this assay, from the lowest: compounds 2, 1 and 3 (each within the scatter of the next).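

In this assay, putting 4-chlorophenyl in place of 2,3-dihydroxyphenyl at this place, ortho to a cyano group, gives a 1.8-fold higher number from compound 2 to compound 3 (0.25 log units; within the scatter), even though the count of hydrogen-bond donors and acceptors drops from 2 of each to 0. Chloro in place of methoxy on an aromatic carbon gives a 1.3-fold higher number from compound 1 to compound 3 (0.11 log units; within the scatter), so this simpler exchange also produces no real difference, and three different substitution patterns on the phenyl ring now cannot be told apart. No other measurement is available to explain why these numbers stay so close.

On these data alone, all three compounds carry a substituted phenyl ring here, so the effect of something quite different at this place remains open. An amine or a carboxylic acid on that ring, or a longer chain in place of the ring, could still move the number beyond the scatter.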